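Hydroxy on compound 3, the core without propyl

This account rests on a few compounds, and the source may have more. Where it says the series, first, only, none or still open, it means among the compounds named here.

In a functional assay on MSTO-211H cells (Homo sapiens) for inhibition, read by trypan blue exclusion, with a stated time of 72 h (on this read-out lower numbers stand for stronger inhibition of growth and higher numbers for weaker inhibition of growth), compound 3 (`Cc1c(-c2ccc(O)cc2)[nH]c2ccccc12`) gives > 20000 nM which is a limit and not a number. The change to compound 4 (`Cc1c(-c2ccc(O)cc2)[nH]c2ccc(O)cc12`) is hydroxy in place of hydrogen on an aromatic carbon with hydroxy in place of hydrogen on an aromatic carbon. The same change was measured on the propyl-bearing pair: compound 1 (`CCCn1c(-c2ccc(O)cc2)c(C)c2ccccc21`) gives 7100 nM and compound 2 (`CCCn1c(-c2ccc(O)cc2)c(C)c2cc(O)ccc21`) gives 2900 nM in this assay for a 2.4-fold lower number from compound 1 to compound 2 (0.39 log units; beyond the scatter) as a modest step. Hydrogen in place of propyl gave an at least 2.8-fold higher number from compound 1 to compound 3 (0.44 log units; beyond the scatter) so the starting point here lies on the weaker side. Expected in this assay is a modest move to a lower number, estimated as an at least 1.4-fold lower number from compound 3 to compound 4 (0.15 log units; that floor lies within the scatter) on the strength of that single pair. The estimate for compound 4 is 14000 nM (expected range 6000 nM to 30000 nM).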

Compound 4, concentration for 50% growth inhibition: > 20000 nM
Compound 4 was reported as a limit; the forecaster's own chance of this, stated with the estimate: 40%; middle value at least 1.4-fold (0.15 log units) away from the limit.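

In this assay compound 4 gives > 20000 nM, which is a limit and not a number. The step that adds hydroxy without propyl cannot be read, so the gain seen with propyl is not confirmed on this core. Hydrogen in place of propyl on the aromatic nitrogen now gives an at least 6.8-fold higher number from compound 2 to compound 4 (0.83 log units; beyond the scatter), so this loss appears on both cores: the same change on two cores in this assay, an at least 2.8-fold higher number (0.44 log units; beyond the scatter) from compound 1 to compound 3 and an at least 6.8-fold higher number (0.83 log units; beyond the scatter) from compound 2 to compound 4; the limit leaves it open whether they differ

On these data alone, whether hydroxy changes growth inhibition at all without propyl stays open at the limit: the limit of > 20000 nM in this assay, at which 2 of the 4 values shown sit. Also open is how a longer chain or a carboxylic acid in place of propyl would read in this assay.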